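The source may report more compounds than this note shows. Statements on the series, on what has been measured and on what is new or still open speak of the compounds shown alone.

Compound 1 `Cc1ccc(-c2ccc(O[C@H]3O[C@H](CO)[C@@H](O)[C@H](O)[C@@H]3O)c(Cl)c2)cc1` gives 7.4 ug/mL in a physicochemical assay for solubility, measured as kinetic solubility, with a stated time of 15 h, at pH 7.4; on this read-out higher numbers stand for higher solubility and lower numbers for lower solubility. Compound 2 `OC[C@H]1O[C@H](Oc2ccc(-c3ccc(Cl)c(C(F)(F)F)c3)cc2Cl)[C@@H](O)[C@@H](O)[C@@H]1O` gives 1 ug/mL in this assay. Of these two numbers compound 1 has the higher; the gap to compound 2 lies beyond the scatter. Compound 3 `O=[N+]([O-])c1cccc(-c2ccc(O[C@H]3O[C@H](CO)[C@@H](O)[C@H](O)[C@@H]3O)c(Cl)c2)c1` is not yet measured in this assay. Compared with compound 1 it carries the change (3-nitrophenyl in place of 4-methylphenyl on an aromatic carbon). Among the measured compounds shown here, no measured pair shows this change, so its size is not known. For compound 3 the expected step is a 1.5-fold lower number from compound 1 to compound 3 (0.17 log units; within the scatter), within or close to the scatter, with the lower side favoured. The estimate for compound 3 is 5 ug/mL, between 1.5 ug/mL and 15 ug/mL.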

Compound 3, solubility: 23 ug/mL
Compound 3: middle estimate off by 4.6-fold (0.66 log units), on the low side; measured number outside the range, above it.
By their numbers in this assay, from the lowest: compound 2; then compound 1; then compound 3.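

Replacing 4-methylphenyl with 3-nitrophenyl on this aromatic carbon gives a 3.1-fold higher number from compound 1 to compound 3 (0.49 log units; beyond the scatter) in this assay, so the read-out responds to a change at this position by more than the scatter. The direction is upward, with the entering group carrying more heavy atoms and hydrogen-bond acceptors. Nothing at hand accounts for the step.

The step combines a new group with a new place on the phenyl ring, so 3-methylphenyl and 4-nitrophenyl would be needed to separate the two. As far as these compounds go, whether a phenyl ring bearing an amine or a carboxylic acid moves the number in the same direction remains open.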